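The source may report more compounds than this note shows. Statements on the series, on what has been measured and on what is new or still open speak of the compounds shown alone.

Compound 1 `O=C(O)CCC/C=C\C[C@H]1C(=O)C[C@@H](O)[C@@H]1/C=C/[C@@H](O)COc1ccccc1` is shown here as one of two compounds, and in an ADME assay on CHO cells for agonist activity at prostacyclin receptor (Homo sapiens), read by HTRF and cAMP accumulation (a higher number here means that more compound is needed for the effect, a lower number that less compound is needed), compound 1 gives "not determined" (no result reported). Within the data shown here, compound 2 `O=C(O)CCC1=CC[C@@H]2[C@@H](/C=C/[C@@H](O)COc3ccccc3)[C@H](O)C[C@@H]2OC1` is the only compound with a reported result. In this assay, as far as these compounds go, compound 2 gives > 10000 nM, which is a limit of the assay rather than a number, so its true position is unknown; one of the two entries sits at this limit (the limit of > 10000 nM in this assay, at which 1 of the 2 values shown sits). Compound 3 `O=C(O)CCCC1=CC[C@@H]2[C@@H](/C=C/[C@@H](O)COc3ccccc3)[C@H](O)C[C@@H]2OC1` has not been measured. It differs from compound 2 by carboxymethyl in place of carboxy on a saturated chain carbon, two bonds along the chain from a double-bonded ring carbon. No measured step of this kind exists among the shown compounds. The step from compound 2 to compound 3 is expected to be an at least 6.6-fold lower number from compound 2 to compound 3 (0.82 log units; beyond the scatter), toward less compound needed, as an estimate resting only on the chain change. Compound 3 is estimated at 1500 nM, with a range from 300 nM to 10000 nM.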

Compound 3, half-maximal effective concentration: > 10000 nM
Compound 3: no number, only a limit; the forecaster's own chance of this, stated with the estimate: 30%; middle value at least 6.6-fold (0.82 log units) from the limit.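

In this assay compound 2 and compound 3 both stand at a limit of the assay rather than at a number, so no step between them can be read: the limit of > 10000 nM in this assay, at which 2 of the 3 values shown sit.

The compounds shown leave open how much of compound 2 or compound 3 is truly needed for the effect, and whether carboxymethyl in place of carboxy changes that at all.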